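The source may hold more compounds than are shown below. What is called first, only, known or untested is meant among the compounds shown, and "the series" means these compounds.

The shared core of compound 2, `Nc1ccc(/C=C2\SC(=O)N(Cc3ccc(Cl)cc3)C2=O)cc1`, carries a 4-aminophenyl group on the exocyclic double bond and a 4-chlorobenzyl group on the ring nitrogen. In a functional assay on L1210 cells (Mus musculus) for cytotoxicity, read by cell counting, with a stated time of 2 days (on this read-out higher numbers stand for weaker inhibition and lower numbers for stronger inhibition), compound 2 gives 37000 nM. This is the lower of the two numbers available, the other belonging to compound 1, `Nc1cccc(/C=C2\SC(=O)N(Cc3ccccc3)C2=O)c1`, which differs from compound 2 in two places at once; in this assay compound 1 gives 233000 nM, a gap that lies beyond the scatter. Since the two compounds differ both in the position of the amino group and in the chlorine on the benzyl group, no single step can be read from them.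

Compound 3, `Nc1cccc(/C=C2\SC(=O)N(Cc3ccc(Cl)cc3)C2=O)c1`, keeps the 4-chlorobenzyl group of compound 2 and changes only the other side: 3-aminophenyl in place of 4-aminophenyl on a double-bonded chain carbon bound to a double-bonded ring carbon. From the compounds shown here alone, how much of the difference between compound 1 and compound 2 belongs to the amino position is unknown, so a moderate rise toward the weaker end is expected, and the step of a 2.4-fold higher number from compound 2 to compound 3 (0.39 log units; beyond the scatter) is the estimate. In this assay compound 3 is expected to give 90000 nM, within a range from 30000 nM to 270000 nM.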

Compound 3, half-maximal inhibitory concentration: 218000 nM
Estimate against measurement, compound 3: 2.4-fold (0.38 log units) below; measured number inside the range.
By their numbers in this assay, from the lowest: compound 2; then compounds 3 and 1 (each within the scatter of the next).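

In this assay, the two aminophenyl groups can now be compared with the 4-chlorobenzyl group held fixed: 3-aminophenyl in place of 4-aminophenyl on a double-bonded chain carbon bound to a double-bonded ring carbon gives a 5.9-fold higher number from compound 2 to compound 3 (0.77 log units; beyond the scatter). With 3-aminophenyl held fixed, chloro in place of hydrogen on an aromatic carbon gives a 1.1-fold lower number from compound 1 to compound 3 (0.03 log units; within the scatter), so this change has no readable effect in this pair. Among the compounds shown here, of the two single changes now available, only the one in the position of the amino group gives a step beyond the scatter, and the chloro step is known only with 3-aminophenyl present.

From the compounds shown here alone, whether chloro in place of hydrogen would give a similarly small step with 4-aminophenyl present remains open, as does what a hydroxyl or a dimethylamino group in place of the amine would give on the phenyl ring. Nothing measured here offers an explanation for the step between the two aminophenyl groups.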